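A few compounds are considered here, and "the series" means these few. Any claim that something is new, unique, unknown or untested is made for them only; others in the source may bear on it.

Compound 1 `COc1cc(-c2cc(/C=C/C(=O)c3ccc(N)cc3)[nH]n2)cc(OC)c1OC`: 104%
Compound 2 `COc1ccc(-c2cc(/C=C/C(=O)c3ccc(N)cc3)[nH]n2)cc1`: 105%

In a functional assay on SK-OV-3 cells (Homo sapiens) for cytotoxicity, read by sulforhodamine B assay, with a stated time of 48 h, tested at 1 uM (a lower number here means a stronger effect, a higher number a weaker effect of the compound at the concentration tested), compound 1 gives 104%, and compound 2 gives 105%; the two numbers lie within the usual scatter of each other, so neither compound shows a clear effect at this concentration. Compound 3 `COc1ccc(C(=O)/C=C/c2cc(-c3cc(OC)c(OC)c(OC)c3)n[nH]2)cc1OC` keeps the shared core and differs from compound 1 in one place: 3,4-dimethoxyphenyl in place of 4-aminophenyl on a carbonyl carbon. Among the compounds with values here, no measured pair shows what such a change does here, and both measured compounds sit near no effect. The step from compound 1 to compound 3 in this assay is therefore expected to be small, a number 6 percentage points lower from compound 1 to compound 3 (within the scatter), with no direction beyond the scatter. Compound 3 is estimated at 98%, between 80% and 110%.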

Compound 3, a percentage reported as activity, at one concentration (the size of the read-out at that concentration, not a potency): 100%
Compound 3: middle estimate off by 2 percentage points, on the low side; low and high end bracket the measured number.
By their numbers in this assay, from the lowest: compounds 3, 1 and 2 (each within the scatter of the next).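

In this assay, putting 3,4-dimethoxyphenyl in place of 4-aminophenyl on a carbonyl carbon gives a number 4 percentage points lower from compound 1 to compound 3 (within the scatter). This position therefore accepts a larger group without a hydrogen-bond donor, and the read-out shows no clear change; compound 3 also shows no clear effect at this concentration. From the compounds shown here alone, what a carboxylic acid or a pyridine ring would do in this place remains open, as does whether this change matters in a compound that shows a clear effect. Nothing available here offers an explanation for this result.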